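A few compounds are considered here, and "the series" means these few. Any claim that something is new, unique, unknown or untested is made for them only; others in the source may bear on it.

The measured compounds and their values:

Compound 1, `Cc1nn(-c2nc(-c3ccc(Cl)c(Cl)c3)c(SC(C)C)s2)c(C(=O)O)c1-c1cc(C#N)cc(C(F)(F)F)c1`, gives 3600 nM in a functional assay on BJAB cells (Homo sapiens) for antiproliferative activity, with a stated time of 4 days; a higher number here means that more compound is needed for the effect, a lower number that less compound is needed.
Compound 2, `Cc1nn(-c2nc(-c3ccc(Cl)c(Cl)c3)c(SC(C)C)s2)c(C(=O)O)c1-c1cc(C(F)(F)F)cc(C(F)(F)F)c1`, gives 1800 nM in this assay.
Compound 3, `Cc1c(-c2cc(Cl)cc(Cl)c2)c(C(=O)O)nn1-c1nc(-c2cc(Cl)ccc2F)c(SC(C)C)s1`, gives 4800 nM in this assay.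

Among these three numbers compound 1 stands second highest. Going by the values given here, its nearest neighbour is compound 3, and the gap between them lies within the scatter; compound 2 is furthest from it, and that gap too lies within the scatter, as the one measured step shows: a 2.0-fold lower number from compound 1 to compound 2 (0.30 log units; within the scatter).

The unmeasured compound 4, `Cc1nn(-c2nc(-c3ccc(Cl)c(Cl)c3)c(SC(C)C)s2)c(C(=O)O)c1-c1cccc(Cl)c1`, differs from compound 1 in one place: 3-chlorophenyl in place of 3-cyano-5-(trifluoromethyl)phenyl on an aromatic carbon. Among the compounds with values here, only the step from compound 1 to compound 2 bears on this change, and only in part, since it swaps the cyano for a trifluoromethyl while the change to compound 4 removes both groups and brings in a single chlorine. That step was within the scatter. Nothing in the data suggests a step beyond the scatter for compound 4, so its number in this assay is expected to stay near that of compound 1, with a 1.3-fold higher number from compound 1 to compound 4 (0.10 log units; within the scatter) as the expected step. Compound 4 is estimated at 4500 nM, within a range from 1500 nM to 13000 nM.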

Compound 4, half-maximal effective concentration: 13600 nM
The estimate for compound 4 lay 3.0-fold (0.48 log units) below the measured number; the whole stated range lies below it.
By their numbers in this assay, from the lowest: compounds 2, 1 and 3 (each within the scatter of the next, the first and the last beyond it); then compound 4.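

The replacement at this position, on the aromatic carbon of the five-membered ring, gave a 3.8-fold higher number from compound 1 to compound 4 (0.58 log units; beyond the scatter) in this assay, so this site can produce a step beyond the scatter, which the swap of nitrile for trifluoromethyl had not shown. The change is a combined one, since it removes the nitrile and the trifluoromethyl together and brings in a chlorine, and these data cannot assign the step to any one of those parts. Nothing available here accounts for the step.

The compounds shown leave open whether a phenyl ring carrying only a trifluoromethyl or only a nitrile would stay close to compound 1 or to compound 4. They also leave open how a methoxy group or an amine in place of the chlorine would read in this assay.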